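The source may hold more compounds than are shown below. What is called first, only, known or untested is meant among the compounds shown, and "the series" means these compounds.

Compounds measured so far:
Compound 1, `COc1cccc(S(=O)(=O)Nc2ccc3oc(-c4ccccc4)nc3c2)c1`: in an assay on isolated protein for inhibition of malate dehydrogenase, mitochondrial (Sus scrofa), with stated times of 45 min and 30 min (a lower number here means a stronger inhibitor, a higher number a weaker inhibitor), compound 1 gives > 63000 nM, which is a limit of the assay and not a number.
Compound 2, `O=S(=O)(Nc1ccc2oc(-c3ccccc3)nc2c1)c1ccccc1O`: in this assay compound 2 gives > 63000 nM, again a limit of the assay rather than a number.

Compound 2 thus stands at the limit of > 63000 nM in this assay, at which 2 of the 2 values shown sit, and no numerical potency is known for it. The step that the two limits leave unreadable from compound 1 to compound 2 cannot be read, as both of its ends are limits. Compound 3, `O=S(=O)(Nc1ccc2oc(-c3ccccc3)nc2c1)c1ccc(Cl)c(Cl)c1`, differs from compound 2 by 3,4-dichlorophenyl in place of 2-hydroxyphenyl on a sulfonyl sulfur. Among the measured compounds shown here, only one measured step bears on this change, and it shows merely that an earlier exchange on the sulfonyl sulfur left both compounds at the limit; no step of readable size exists. Compound 3 is expected to stay near that limit, with an estimate of 60000 nM, ranging from 15000 nM to 250000 nM. The expected step in this assay, an at least 1.0-fold lower number from compound 2 to compound 3 (0.02 log units; that floor lies within the scatter), is one of no readable size.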

Compound 3, half-maximal inhibitory concentration: > 63000 nM
Compound 3 ended at the assay's limit; the forecaster's own chance of this, stated with the estimate: 65%; middle value at least 1.0-fold (0.02 log units) away from the limit.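

In this assay compound 3 gives > 63000 nM, a limit of the assay and not a number. Its steps from compound 1 and compound 2 therefore cannot be read. The compounds shown leave open whether any group on the sulfonyl sulfur of the shared core would give a numerical potency in this assay.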